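This account rests on a few compounds, and the source may have more. Where it says the series, first, only, none or still open, it means among the compounds named here.

Measured in a functional assay on A549 cells (Homo sapiens) for inhibition, read by sulforhodamine B assay; on this read-out higher numbers stand for weaker inhibition of growth and lower numbers for stronger inhibition of growth:
- compound 1 `c1ccc(-c2ccc(-c3ccc(-c4nc5ccccc5[nH]4)cc3)cc2)cc1`: 41200 nM
- compound 2 `COc1ccc(-c2ccc(-c3ccc(-c4nc5cc(C)ccc5[nH]4)cc3)cc2)cc1OC`: 2100 nM
- compound 3 `COc1cc(-c2ccc(-c3ccc(-c4nc5cc(C)ccc5[nH]4)cc3)cc2)cc(OC)c1OC`: < 100 nM, a limit

Compound 1 holds the highest number shown, and compound 2 stands below it, beyond the scatter. Compound 4 `FC(F)(F)c1ccc(-c2ccc(-c3ccc(-c4nc5ccccc5[nH]4)cc3)cc2)cc1` takes trifluoromethyl in place of hydrogen on an aromatic carbon, para to a large group: trifluoromethyl in place of hydrogen on an aromatic carbon. Within the data shown here, one measured step bears on this, and only loosely: an at least 21-fold lower number from compound 2 to compound 3 (1.32 log units; beyond the scatter). It is large, but it adds methoxy and ends at a limit. Among the measured compounds shown here, no measured step adds trifluoromethyl. A modest move towards a lower number in this assay is expected, much smaller than that large step. The expected step is a 2.7-fold lower number from compound 1 to compound 4 (0.44 log units; beyond the scatter). For compound 4 the estimate is 15000 nM, with an expected range of 3000 nM to 60000 nM.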

Compound 4, concentration for 50% growth inhibition: 36600 nM
Estimate against measurement, compound 4: 2.4-fold (0.39 log units) below; the measured number falls inside the stated range.
By their numbers in this assay, from the lowest: compound 2; then compounds 4 and 1 (each within the scatter of the next). At a limit, below all of these: compound 3.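

In this assay, trifluoromethyl on an aromatic carbon, para to a large group, on the core of compound 1 gives no change beyond the scatter (a 1.1-fold lower number from compound 1 to compound 4 (0.05 log units; within the scatter)). Among these compounds, the only earlier step, which added methoxy on a different core, was large, so this result shows that an added group on this ring need not move the number. Nothing measured here gives a cause for this result. On these data alone, whether an amine or a carboxylic acid at this position would also leave the number unchanged stays open. So does whether methoxy would act on the core of compound 1 as it did on compound 2.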